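A few compounds are considered here, and "the series" means these few. Any claim that something is new, unique, unknown or untested is made for them only; others in the source may bear on it.

Of the compounds shown here, three have been measured. Compound 1 `COc1cc(C)ccc1S(=O)(=O)N1CCC(N2CCC(C)CC2)CC1` gives, in an ADME assay on HCT-116 cells (Homo sapiens) for cytotoxicity, read by CellTiter-Glo, with a stated time of 72 h (on this read-out higher numbers stand for weaker inhibition and lower numbers for stronger inhibition), > 5000 nM. Compound 2 `CC1CCN(C2CCN(S(=O)(=O)c3cnc(Cl)s3)CC2)CC1` gives in this assay > 10000 nM. Compound 3 `CCCC(=O)NC1CCN(S(=O)(=O)c2c(C)cc(C)cc2C)CC1` gives in this assay > 5000 nM.

Each of these results is a limit of the assay and not a number. Compound 2 stands at the limit of > 10000 nM in this assay, at which 1 of the 3 values shown sits, so its result is a limit only and no order among the three can be read from it. The other two compounds sit at the limit of > 5000 nM in this assay, at which 2 of the 3 values shown sit, also limits only.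

Compound 4 `CC1CCN(C2CCN(S(=O)(=O)c3ccc(Cl)c(Cl)c3)CC2)CC1` differs from compound 2 in one place: 3,4-dichlorophenyl in place of 2-chloro-1,3-thiazol-5-yl on a sulfonyl sulfur. Within the data shown here, no measured pair differing in a single place is available in this assay, so the size of this step is not known from the data. Since every measured compound, whatever its sulfonyl substituent, returns a limit in this assay, the step from compound 2 to compound 4 is expected to be none beyond the scatter, a step that the limit leaves unreadable from compound 2 to compound 4. Compound 4 is therefore expected to give 15000 nM, within 5000 nM to 50000 nM, most probably again as a limit.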

Compound 4, half-maximal inhibitory concentration: > 5000 nM
Compound 4: no number, only a limit (the forecaster's own chance of this, stated with the estimate: 85%); the middle value lies beyond the limit too.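

Compound 2 and compound 4 both return only limits in this assay, so the step between them cannot be read. The compounds shown leave open whether changing the group on the sulfonyl sulfur alters the result in this assay, and by how much.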